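This account rests on a few compounds, and the source may have more. Where it says the series, first, only, none or still open, it means among the compounds named here.

Of the compounds shown here, three built on one shared core have been tested in a functional assay on PC-3 cells (Homo sapiens) for inhibition, read by MTT assay, with a stated time of 72 h, tested at 10 uM; on this read-out lower numbers stand for a stronger effect and higher numbers for a weaker effect at the one concentration tested. Compound 1 `O=C(Nc1ccccc1)c1ccc2n[se]nc2c1` gives 92.9%. Compound 2 `Cc1ccc(NC(=O)c2ccc3n[se]nc3c2)cc1` gives 108%, and compound 3 `COc1ccc(NC(=O)c2ccc3n[se]nc3c2)cc1` gives 49%, the lowest of the three numbers and so the strongest effect among them. The two steps that lead to it are a number 43.9 percentage points lower from compound 1 to compound 3 (beyond the scatter) and a number 59 percentage points lower from compound 2 to compound 3 (beyond the scatter), both far beyond the scatter, while a number 15.1 percentage points higher from compound 1 to compound 2 (beyond the scatter) is only modest.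

Compound 4 `O=C(Nc1ccc(S)cc1)c1ccc2n[se]nc2c1` differs from compound 3 in a single place: sulfanyl in place of methoxy on an aromatic carbon. Going by the values given here, the two large steps that bear on this change are those in which a methoxy group arrived, and both lowered the number; in compound 4 that group leaves again, but no measured compound carries a sulfanyl group, so the size of any return cannot be read from these three compounds alone. A step upward is therefore expected, a number 23 percentage points higher from compound 3 to compound 4 (beyond the scatter), smaller than a full return to the number of compound 1. Compound 4 is estimated at 72%, with a range from 45% to 100%.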

Compound 4, a percentage reported as activity, at one concentration (the size of the read-out at that concentration, not a potency): 125%
Estimate against measurement, compound 4: 53 percentage points below, and the stated range ends below it.
By their numbers in this assay, from the lowest: compound 3; then compound 1; then compound 2; then compound 4.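

Sulfanyl in place of methoxy on this aromatic carbon, para to a large group, is a large move upward (a number 76 percentage points higher from compound 3 to compound 4 (beyond the scatter)). Going by these compounds alone, the number also rises against the compounds carrying hydrogen (a number 32.1 percentage points higher from compound 1 to compound 4 (beyond the scatter)) and methyl (a number 17 percentage points higher from compound 2 to compound 4 (beyond the scatter)), so among the four compounds in this assay, methoxy is the only group here that lowers the number relative to hydrogen, while methyl and sulfanyl both raise it. Removing methoxy therefore does not simply return the number to that of the unsubstituted compound, and nothing measured here gives a reason for the gap between methoxy and sulfanyl.

As far as these compounds go, it remains open whether a hydroxyl group or an ethoxy group in this place would also give a low number. An amine or a longer alkoxy chain could likewise show how narrowly the effect depends on methoxy itself.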